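The source may hold more compounds than are shown below. What is called first, only, known or untested is meant among the compounds shown, and "the series" means these compounds.

Working notes on the series. Compound 1 `CC(C)C[C@H](NC(=O)CNC(=O)CC[C@H](NS(=O)(=O)c1ccc(Cl)c(C(F)(F)F)c1)C(=O)O)C(=O)N[C@H](C(=O)N[C@@H](C)C(N)=O)C(C)C` is the peptide sulfonamide of the set; in an assay on isolated protein for inhibition of matrix metalloproteinase-9 (Homo sapiens), read by fluorescence, with a stated time of 15 min (on this read-out lower numbers stand for stronger inhibition and higher numbers for weaker inhibition), compound 1 gives no number, only the limit > 100000 nM. Compound 2 `O=C(O)[C@H](CCc1ccccc1)NS(=O)(=O)c1ccc(Cl)c(C(F)(F)F)c1` is the short acid; in this assay compound 2 also returns only the limit > 100000 nM. Both readings therefore fall at the same boundary, (the limit of > 100000 nM in this assay, at which 2 of the 2 values shown sit), and compound 1 stands at that limit rather than at a measured number, with no ordering possible against the other value shown.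

Compound 3 `CSCC[C@H](NC(=O)[C@H](CC(C)C)NC(=O)CNC(=O)CC[C@H](NS(=O)(=O)c1ccc(Cl)c(C(F)(F)F)c1)C(=O)O)C(N)=O` differs from compound 1 in one place: 1-carbamoyl-3-(methylsulfanyl)propyl in place of 1-((1-carbamoylethyl)carbamoyl)-2-methylpropyl on an amide-type nitrogen. Among the compounds with values here, no step between two measured compounds is known, and the two limits give no direction for this change; the step that the limit leaves unreadable from compound 1 to compound 3 is expected to be none beyond the scatter, with the assay most likely reporting a limit again. For compound 3 an inhibitory concentration of roughly 150000 nM is estimated, between 30000 nM and 1000000 nM.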

Compound 3, half-maximal inhibitory concentration: > 100000 nM
Compound 3 ended at the assay's limit; the forecaster's own chance of this, stated with the estimate: 85%; the middle value does not contradict the limit.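

The step from compound 1 to compound 3 cannot be read, as both compounds sit at one limit, not at a number: the limit of > 100000 nM in this assay, at which 3 of the 3 values shown sit. The compounds shown leave open how the change on the amide-type nitrogen affects inhibition, and how compounds 1, 2 and 3 rank.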